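A few compounds are considered here, and "the series" means these few. Any claim that something is new, unique, unknown or untested is made for them only; others in the source may bear on it.

Four acids of one family were brought together here. Compound 2 `O=C(O)CC/C=C\CC1=CCC[C@@H]1NS(=O)(=O)c1ccc(F)cc1` serves as the point of departure; in a functional assay on a cell-free system (plasma) for inhibition of thromboxane A2 receptor (Homo sapiens), read by turbidimetry (a lower number here means a stronger inhibitor, a higher number a weaker inhibitor), compound 2 gives 1300 nM. Compound 1 `O=C(O)CCC/C=C\C[C@H]1[C@H](F)CC[C@@H]1NS(=O)(=O)c1cccc2cccnc12` has a core and a chain that differ from those of the point of departure; in this assay compound 1 gives 2000 nM. Compound 3 `O=C(O)CCC/C=C\CC1=CCC[C@@H]1NS(=O)(=O)c1ccc(F)cc1` carries a longer chain than the point of departure; in this assay compound 3 gives 4400 nM; 4400 nM (2 entries). Among the single numbers compound 2 has the lowest, but its separation from compound 1 lies within the scatter, so no order can be read between the two, and the entries for compound 3 stand beside them as a further point of comparison rather than as a ranking.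

Compound 4 `Cc1ccc(S(=O)(=O)N[C@H]2CCC=C2C/C=C\CCC(=O)O)cc1` remains to be measured. It differs from compound 2 in a single place: methyl in place of fluoro on an aromatic carbon. Going by the values given here, no measured pair in this set shows that change, so the data give no size and no direction for it. Nothing in the measured numbers points to a large step from so small an exchange. Compound 4 is therefore expected to give about 1500 nM in this assay, with a range from 600 nM to 4000 nM. This estimate corresponds to a 1.2-fold higher number from compound 2 to compound 4 (0.06 log units; within the scatter), a step expected to lie within the scatter.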

Compound 4, half-maximal inhibitory concentration: 1800 nM
Estimate against measurement, compound 4: 1.2-fold (0.08 log units) below; the measured number falls inside the stated range.
By their numbers in this assay, from the lowest: compounds 2, 4 and 1 (each within the scatter of the next).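

In this assay, going by these compounds alone, the exchange of fluoro for methyl on an aromatic carbon, para to a large group, gives a 1.4-fold higher number from compound 2 to compound 4 (0.14 log units; within the scatter), the first measured reading of this change in the set. Within the data shown here, on this pair, then, 4-fluorophenyl and 4-methylphenyl cannot be told apart at this position, and the single step gives no direction for the exchange and says nothing about how it would read on another core or chain. The data offer no measurement that would account for this result.

Going by these compounds, it remains open whether another group at the same place, such as chloro, methoxy, trifluoromethyl or an amine, or plain hydrogen, would move the number beyond the scatter, so the tolerance of this position is known only for fluoro and methyl. On these data alone, it is also open whether the 4-methylphenyl group would read the same when carried on the longer chain of compound 3 or on the core and chain of compound 1, since the exchange has been read on one chain and one core only.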